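Aryl Ketone Exchange on the Carbonyl: Expecting Compound 3

The compounds below may be only part of what the source reports. "The series", "measured", "known", "first", "only" and "open" are said of these compounds alone.

Measured compounds:
Compound 1 `COc1ccc(C(=O)/C=C/c2nc3ccccc3cc2-c2ccc(OC)cc2)cc1` in a functional assay on MDA-MB-231 cells (Homo sapiens) for antiproliferative activity, read by XTT assay, with a stated time of 72 h; on this read-out lower numbers stand for stronger inhibition and higher numbers for weaker inhibition: 7540 nM
Compound 2 `COc1ccc(-c2cc3ccccc3nc2/C=C/C(=O)c2c(OC)cccc2OC)cc1` in this assay: 5630 nM

Compound 2 holds the lowest of the two numbers, with compound 1 nearest; the step of a 1.3-fold lower number from compound 1 to compound 2 (0.13 log units; within the scatter) lies within the scatter, so no order between the two is claimed.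

Compound 3 `COc1ccc(-c2cc3ccccc3nc2/C=C/C(=O)c2ccc(N)cc2)cc1` differs from compound 2 by 4-aminophenyl in place of 2,6-dimethoxyphenyl on a carbonyl carbon. Among the measured compounds shown here, the only measured step, a 1.3-fold lower number from compound 1 to compound 2 (0.13 log units; within the scatter), likewise exchanged the aryl group on the carbonyl carbon and stayed within the scatter. For the measured compounds named here, no measured step introduces an aminophenyl group, so the data give no direct guide for that feature. On this basis no step beyond the scatter is expected in this assay in either direction. Compound 3 is therefore estimated at 5000 nM, with a range from 1500 nM to 16000 nM. That estimate means an expected step of a 1.1-fold lower number from compound 2 to compound 3 (0.05 log units; within the scatter).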

Compound 3, half-maximal inhibitory concentration: 7510 nM
Estimate against measurement, compound 3: 1.5-fold (0.18 log units) below; the range from low to high includes it.
By their numbers in this assay, from the lowest: compounds 2, 3 and 1 (each within the scatter of the next).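

In this assay the exchange on the carbonyl carbon gives a 1.3-fold higher number from compound 2 to compound 3 (0.13 log units; within the scatter), so this position has now carried a group with a hydrogen-bond donor, 4-aminophenyl, as well as 2,6-dimethoxyphenyl, with no step beyond the scatter. The narrower exchange of amino in place of methoxy on an aromatic carbon gives a 1.0-fold lower number from compound 1 to compound 3 (0.00 log units; within the scatter), so neither change separates the compounds in this read-out. Nothing available explains why these numbers lie so close together.

On these data alone, all three groups on the carbonyl carbon are six-membered aromatic rings of carbon only, so it remains open whether a pyridine ring or a cyclohexyl group there would give a step beyond the scatter. As far as these compounds go, whether a carboxylic acid or a dimethylamino group in place of the amino would do so is equally open.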